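Series notes: cytotoxicity in mouse macrophages, compound 2 to compound 3

A few compounds are considered here, and "the series" means these few. Any claim that something is new, unique, unknown or untested is made for them only; others in the source may bear on it.

Measured so far in an ADME assay on J774.1 cells (Mus musculus) for cytotoxicity, read by resazurin assay, with a stated time of 48 h; a lower number here means a stronger inhibitor, a higher number a weaker inhibitor:
compound 1 `CCCCn1cc(C(=O)NCc2ccccc2)c(=O)c2cc(F)c(-c3ccccc3)cc21` — > 100000 nM
compound 2 `CCCCn1cc(C(=O)NCc2ccc([N+](=O)[O-])cc2)c(=O)c2cc(F)c(N3CCC(C(N)=O)CC3)cc21` — > 100000 nM

Neither entry is a number. For compound 1 the value > 100000 nM is a limit of the assay. For compound 2 the value > 100000 nM is likewise a limit of the assay. Among the measured compounds shown here, compound 2 therefore stands at the limit of > 100000 nM in this assay, at which 2 of the 2 values shown sit, and no measured step between the two compounds exists to set a scale for the series.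

The next compound, compound 3 `CCCCn1cc(C(=O)NCc2ccccc2)c(=O)c2cc(F)c(N3CCC(C(N)=O)CC3)cc21`, differs from compound 2 in one place: hydrogen in place of nitro on an aromatic carbon. For the measured compounds named here, with compound 2 already at the limit and no measured step to lean on, no change beyond the usual scatter is expected in this assay; the expected step is a step that the limit leaves unreadable from compound 2 to compound 3. Compound 3 is thus estimated at 150000 nM, with a range from 50000 nM to 500000 nM, most likely reported again as a limit rather than a number.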

Compound 3, half-maximal inhibitory concentration: 47000 nM
For compound 3 the middle estimate is 3.2-fold (0.50 log units) above the measured one, outside the stated range (below it).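

In this assay, hydrogen in place of nitro, which turns 4-nitrobenzyl into benzyl, gives an at least 2.1-fold lower number from compound 2 to compound 3 (0.32 log units; beyond the scatter). Among the compounds shown here, this is the first sign that the series can leave the limit through a change on this aromatic ring. With the benzyl group kept, 4-carbamoylpiperidin-1-yl in place of phenyl on an aromatic carbon gives an at least 2.1-fold lower number from compound 1 to compound 3 (0.32 log units; beyond the scatter), so a second site in the series also moves the read-out, and both steps give only a minimum size because each starts from a limit: the limit of > 100000 nM in this assay, at which 2 of the 3 values shown sit.

From the compounds shown here alone, the true size of either step stays open. Also open, going by these compounds, is what an amine or a methoxy group in place of that hydrogen would give on the benzyl ring, and what a carboxylic acid in place of the carbamoyl group would give on the piperidine.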